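Glucokinase regulatory protein series: sulfonamide to trifluoromethyl diol

The source may report more compounds than this note shows. Statements on the series, on what has been measured and on what is new or still open speak of the compounds shown alone.

Measured so far in an assay on cells (Hepatocyte) for inhibition of glucokinase regulatory protein (Mus musculus), with stated times of 20 min and 40 min; a higher number here means that more compound is needed for the effect, a lower number that less compound is needed:
compound 1 `CC#C[C@H]1CN(S(=O)(=O)c2ccc(N)nc2)CCN1c1ccc(S(=O)(=O)NCC2CC2)cc1` gives 271 nM
compound 2 `CC#C[C@H]1CN(S(=O)(=O)c2ccc(N)nc2)CCN1c1ncc(C(O)(C(F)(F)F)C(F)(F)F)cn1` gives 2200 nM
compound 3 `CC#C[C@H]1CN(S(=O)(=O)c2ccc(N)nc2)CCN1c1ccc(C(C)(O)C(F)(F)F)nc1` gives 1450 nM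

Compound 1 has the lowest number of the three; compound 3 stands nearest and compound 2 furthest, both beyond the scatter. Compound 4 `CC#C[C@H]1CN(S(=O)(=O)c2ccc(N)nc2)CCN1c1ccc([C@](O)(CO)C(F)(F)F)cc1` keeps the shared core of compound 1 and differs in one place: 1,2-dihydroxy-1-(trifluoromethyl)ethyl in place of (cyclopropylmethyl)sulfamoyl on an aromatic carbon the place is para to a large group. Among the measured compounds shown here, no measured pair isolates this change. Compounds 2 and 3, which also carry a trifluoromethyl carbinol on the ring attached to the core, both give higher numbers than compound 1, so a step up beyond the scatter is expected, a 2.8-fold higher number from compound 1 to compound 4 (0.44 log units; beyond the scatter). Compound 4 is estimated at 750 nM, within 250 nM to 2200 nM.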

Compound 4, half-maximal effective concentration: 98 nM
For compound 4 the middle estimate is 7.7-fold (0.88 log units) above the measured one; the whole stated range lies above it.
By their numbers in this assay, from the lowest: compound 4; then compound 1; then compounds 3 and 2 (each within the scatter of the next).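

In this assay, the place para to a large group does not depend on (cyclopropylmethyl)sulfamoyl: 1,2-dihydroxy-1-(trifluoromethyl)ethyl gives a 2.8-fold lower number from compound 1 to compound 4 (0.44 log units; beyond the scatter) and is a modest gain. The sulfonamide and its three-membered ring can therefore be replaced at this place without losing the effect. No evidence available here bears on why the number falls. Still open, going by these compounds, is whether the opposite configuration at the defined stereocentre gives a similar number. Also open, on these data alone, is how a carboxylic acid or a simple hydroxymethyl would fare at this place.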